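A few compounds are considered here, and "the series" means these few. Any claim that something is new, unique, unknown or untested is made for them only; others in the source may bear on it.

Series notes on the benzamide pair and their hydroxamic counterparts.

Compound 1 `Nc1ccccc1NC(=O)c1ccc(CNCc2nc(-c3ccc(F)cc3)no2)cc1` is the reference of the set; in a functional assay on NCI-H661 cells (Homo sapiens) for inhibition, read by MTT assay, with a stated time of 72 h (on this read-out lower numbers stand for stronger inhibition and higher numbers for weaker inhibition), compound 1 gives 4360 nM. Compound 2 `Nc1ccccc1NC(=O)c1ccc(CNCc2nc(-c3cccs3)no2)cc1` differs from compound 1 by thiophen-2-yl in place of 4-fluorophenyl on an aromatic carbon, and in this assay compound 2 gives 35800 nM, so the step is an 8.2-fold higher number from compound 1 to compound 2 (0.91 log units; beyond the scatter). Compound 3 `O=C(NO)c1ccc(CNCc2nc(-c3ccc(F)cc3)no2)cc1` carries a different core, the difference from compound 1 being (hydroxy in place of 2-aminophenyl on an amide-type nitrogen). In this assay compound 3 gives only a limit of the assay, > 100000 nM. The step of an at least 22-fold higher number from compound 1 to compound 3 (1.36 log units; beyond the scatter) is accordingly a bound only, fixed by the limit of > 100000 nM in this assay, at which 1 of the 3 values shown sits.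

Compound 4 `O=C(NO)c1ccc(CNCc2nc(-c3cccs3)no2)cc1` has not been measured. Among the measured compounds shown here, it differs from compound 3 by thiophen-2-yl in place of 4-fluorophenyl on an aromatic carbon, which is the same change as the one separating compound 1 from compound 2, made at the same place. On the core of compound 1 that change gave an 8.2-fold higher number from compound 1 to compound 2 (0.91 log units; beyond the scatter), a weakening. Compound 3 already rests at the limit of > 100000 nM in this assay, at which 1 of the 3 values shown sits, so the same change made on the core of compound 3 is expected to move compound 4 no nearer to a measurable number. The expected step is estimated as a step that the limit leaves unreadable from compound 3 to compound 4, resting on the weakening seen as an 8.2-fold higher number from compound 1 to compound 2 (0.91 log units; beyond the scatter). For compound 4 in this assay the expected value is therefore 250000 nM, within an estimated range from 90000 nM to 1000000 nM, and it is most likely that the assay would again report only a limit.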

Compound 4, half-maximal inhibitory concentration: > 100000 nM
Compound 4 gave a limit, no number (the forecaster's own chance of this, stated with the estimate: 85%); the middle value is on the limit's open side.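

In this assay compound 4 gives > 100000 nM, which is a limit of the assay and not a number, so the change of 4-fluorophenyl to thiophen-2-yl cannot be read on the core of compound 3, and the weakening seen on the core of compound 1 is neither confirmed nor contradicted there. Hydroxy in place of 2-aminophenyl on the amide-type nitrogen, now also seen with thiophen-2-yl on the oxadiazole-bearing side of the molecule, gives an at least 2.7-fold higher number from compound 2 to compound 4 (0.44 log units; beyond the scatter), so that change goes the same way in both pairs, compound 1 with compound 3 and compound 2 with compound 4. Its size cannot be compared between the two pairs: the same change on two cores in this assay, an at least 22-fold higher number (1.36 log units; beyond the scatter) from compound 1 to compound 3 and an at least 2.7-fold higher number (0.44 log units; beyond the scatter) from compound 2 to compound 4; the limit leaves it open whether they differ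

Still open, as far as these compounds go, is whether the thiophen-2-yl change has any real size on the core of compound 3, which only measured numbers for compound 3 and compound 4 could show. Also open, from the compounds shown here alone, is how the series responds to other groups at the same two places, such as an unsubstituted phenyl in place of 4-fluorophenyl, or a carboxylic acid in place of the hydroxamic end.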